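The source may hold more compounds than are shown below. What is called first, only, known or untested is meant among the compounds shown, and "the series" means these compounds.

Compound 2, `Cc1c(C)c2ccc(OCC3CCN(Cc4ccc(CCO)cc4)CC3)cc2oc1=O`, is one of two compounds with a result in an assay for inhibition of Amine oxidase [flavin-containing] A (Homo sapiens), read by fluorescence, using microsomes, with a stated time of 30 min; on this read-out lower numbers stand for stronger inhibition and higher numbers for weaker inhibition. In this assay compound 2 gives 1700 nM, the lower of the two numbers. The other measured compound is compound 1, `Cc1cc2ccc(OCC3CCN(Cc4cccc(CO)c4)CC3)cc2oc1=O`; in this assay compound 1 gives 3900 nM, a higher number by a margin that lies beyond the scatter of repeated measurements, so compound 2 reads as the stronger inhibitor of the pair. Compound 1 differs from compound 2 in more than one place, so the gap between them cannot be tied to any single change.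

Compound 3, `Cc1c(C)c2ccc(OCC3CCN(Cc4cccc(CO[N+](=O)[O-])c4)CC3)cc2oc1=O`, has not yet been measured. It keeps the shared core of compound 2 and differs in one place: 3-((nitrooxy)methyl)phenyl in place of 4-(2-hydroxyethyl)phenyl on a saturated chain carbon bound to an amine nitrogen in a ring. For the measured compounds named here, no measured pair isolates this change, and the only other data point, compound 1, carries a different core as well as a different side group. The expected step is therefore of modest size and uncertain direction, a 1.5-fold higher number from compound 2 to compound 3 (0.17 log units; within the scatter), likely within or just beyond the usual scatter. On that basis compound 3 is expected to give about 2500 nM, with a range from 800 nM to 8000 nM.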

Compound 3, half-maximal inhibitory concentration: 230 nM
The estimate for compound 3 lay 11-fold (1.04 log units) above the measured number, outside the stated range (below it).
By their numbers in this assay, from the lowest: compound 3; then compound 2; then compound 1.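

In this assay, putting 3-((nitrooxy)methyl)phenyl in place of 4-(2-hydroxyethyl)phenyl on a saturated chain carbon bound to an amine nitrogen in a ring gives a 7.4-fold lower number from compound 2 to compound 3 (0.87 log units; beyond the scatter), so a change at this one place alone can move the read-out well beyond the usual scatter. The earlier pair could not show this: compound 1 and compound 2 differ in more than one place, so their gap could not be tied to any single position. The entering group has no hydrogen-bond donor and adds a nitrogen and more oxygen, but nothing measured here explains the stronger inhibition.

This single step changes the end group, the chain and the place of the chain on the aromatic ring all at once, so the compounds shown cannot say which of these changes accounts for the shift. A 3-(2-hydroxyethyl)phenyl group or a 4-((nitrooxy)methyl)phenyl group on the same core would begin to separate these changes, and a 3-(aminomethyl)phenyl group would test a different end group at this place.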